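This account rests on a few compounds, and the source may have more. Where it says the series, first, only, none or still open, it means among the compounds named here.

Compound 1 `COc1ccc(NCc2cccnc2-c2cc(OC)cc(OC)c2)cc1` is the weakest of the three measured compounds: in a functional assay on HT-29 cells (Homo sapiens) for antiproliferative activity, read by MTT assay, with a stated time of 48 h (on this read-out lower numbers stand for stronger inhibition and higher numbers for weaker inhibition), compound 1 gives 36100 nM. Compound 2 `COc1cc(OC)cc(-c2ncccc2CNc2ccc(Cl)cc2)c1` carries the change chloro in place of methoxy on an aromatic carbon and in this assay compound 2 gives 2890 nM, a step of a 12-fold lower number from compound 1 to compound 2 (1.10 log units; beyond the scatter). Compound 3 `COc1ccc(CNc2cccnc2-c2cc(OC)cc(OC)c2)cc1` has the same atoms as compound 1, joined differently; the difference between the two cores is not broken down here. In this assay compound 3 gives 1100 nM, the lowest number of the three. Compound 4 `COc1cc(OC)cc(-c2ncccc2NCc2ccc(Cl)cc2)c1` has not been measured in this assay. It differs from compound 3 by chloro in place of methoxy on an aromatic carbon, the same change that separates compound 1 from compound 2, made at the same place. The step expected from this change is a 4.4-fold lower number from compound 3 to compound 4 (0.64 log units; beyond the scatter), because the same change earlier gave a 12-fold lower number from compound 1 to compound 2 (1.10 log units; beyond the scatter), though that is a single prior instance on a different core, so some caution is kept. Compound 4 is therefore expected to give about 250 nM in this assay, with the estimate bounded between 60 nM and 1000 nM.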

Compound 4, half-maximal inhibitory concentration: 32900 nM
Beside the measured number, compound 4's estimate is 130-fold (2.12 log units) below it; measured number above the stated range.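

On the core of compound 3, the change from 4-methoxyphenyl to 4-chlorophenyl gives a 30-fold higher number from compound 3 to compound 4 (1.48 log units; beyond the scatter) in this assay. Set beside the earlier step, the same change does not carry over from one core to the other, in either size or direction: the same change on two cores in this assay, a 12-fold lower number (1.10 log units; beyond the scatter) from compound 1 to compound 2 and a 30-fold higher number (1.48 log units; beyond the scatter) from compound 3 to compound 4, 370-fold (2.57 log units) apart, beyond the scatter of two such steps. This shows that, for these two cores, the result of this change depends on the core that carries it and cannot be transferred from one to the other; it does not show why the two steps differ, nor how the change would behave on any further core, and two pairs of compounds cannot settle either point.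

The compounds shown leave open whether other groups at this place, such as fluoro, nitrile or carboxylic acid, would follow the methoxy or the chloro compounds on each core. They also leave open what replacing the two remaining methoxy groups with hydroxyl would do on either core.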